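This account rests on a few compounds, and the source may have more. Where it says the series, first, only, none or still open, it means among the compounds named here.

In a functional assay on K562 cells (Homo sapiens) for cytotoxicity, read by MTT assay, with a stated time of 5 days (a lower number here means a stronger inhibitor, a higher number a weaker inhibitor), compound 1 `COc1ccc(-c2cnnn2Cc2cc(OC)c(OC)c(OC)c2)cc1Br` gives > 10000 nM, which is a limit of the assay and not a number. Compound 2 `COc1ccc(-c2cn(Cc3cc(OC)c(OC)c(OC)c3)nn2)cc1Br` gives > 10000 nM, which is likewise a limit and not a number. Compound 2 therefore has no numeric standing, and the whole record so far reads (the limit of > 10000 nM in this assay, at which 2 of the 2 values shown sit). For the measured compounds named here, no measured step exists to serve as a guide.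

Compound 3 `COc1ccc(-c2cn(Cc3cc(OC)c(OC)c(OC)c3)nn2)cc1N` is the next reading. It departs from compound 2 at a single place, (amino in place of bromo on an aromatic carbon). In this way 3-bromo-4-methoxyphenyl becomes 3-amino-4-methoxyphenyl.

Going by the values given here, the only anchor is compound 2 at > 10000 nM, a limit, so the new reading may well stay a limit too. In this assay, the expected change is a modest one toward stronger inhibition, estimated as an at least 1.6-fold lower number from compound 2 to compound 3 (0.22 log units; that floor lies within the scatter), and this rests on the structural change alone. For compound 3 the estimate is 6000 nM, with an expected range of 500 nM to 20000 nM.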

Compound 3, half-maximal inhibitory concentration: > 10000 nM
Compound 3 was reported as a limit; the forecaster's own chance of this, stated with the estimate: 55%; middle value at least 1.6-fold (0.22 log units) away from the limit.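

In this assay compound 3 gives > 10000 nM, a limit and not a number, so the swap of bromo for amino between compound 2 and compound 3 cannot be read as a step. The record now reads: the limit of > 10000 nM in this assay, at which 3 of the 3 values shown sit. The compounds shown leave open whether any change to the shared core gives a numeric value in this assay.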